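The source may hold more compounds than are shown below. What is called first, only, known or untested is meant among the compounds shown, and "the series" means these compounds.

The measured compounds so far:

Compound 1, `O=S(=O)(/C=C/c1ncccc1Cl)c1ccc(F)cc1`, which in an assay on U2OS cells for activation of nuclear factor erythroid 2-related factor 2 (Homo sapiens), read by beta-arrestin recruitment, with a stated time of 6 h (on this read-out higher numbers stand for an effect only at larger amounts of compound and lower numbers for an effect already at smaller amounts), gives 231 nM.
Compound 2, `O=S(=O)(/C=C/c1ncccc1Cl)c1ccc(Cl)cc1`, which in this assay gives 65 nM.
Compound 3, `O=S(=O)(/C=C\c1cccnc1Cl)c1ccccc1F`, which in this assay gives 3390 nM.

Compound 1 and compound 2 share one core and differ in a single place: chloro in place of fluoro on an aromatic carbon. That exchange made a step of a 3.6-fold lower number from compound 1 to compound 2 (0.55 log units; beyond the scatter). Compound 3 is built from the same atoms as compound 1, joined differently, and the difference between the two cores is not broken down here; what the numbers show is that compound 3 sits well above both compound 1 and compound 2 in this assay.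

Compound 4, `O=S(=O)(/C=C\c1cccnc1Cl)c1ccccc1Cl`, has not yet been measured. It comes from compound 3 by the change (chloro in place of fluoro on an aromatic carbon). For the measured compounds named here, this is the same kind of change as the one from compound 1 to compound 2, but not the same: in the measured pair the exchanged group sits para to a large group, whereas in compound 3 and compound 4 it sits ortho to a large group. Going by the values given here, only one example of this exchange has been measured, and it is at a different place, so the expectation is a step of about the same direction but with wider uncertainty: for compound 4 the estimated step is a 2.8-fold lower number from compound 3 to compound 4 (0.45 log units; beyond the scatter) in this assay, resting on the step from compound 1 to compound 2 of a 3.6-fold lower number from compound 1 to compound 2 (0.55 log units; beyond the scatter). The estimate for compound 4 in this assay is therefore 1200 nM, expected to fall between 400 nM and 3500 nM.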

Compound 4, half-maximal effective concentration: 384 nM
Beside the measured number, compound 4's estimate is 3.1-fold (0.49 log units) above it, and the stated range ends above it.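

For the compounds shown here, exchanging fluoro for chloro on the aromatic ring lowered the number again in this assay, with an 8.8-fold lower number from compound 3 to compound 4 (0.95 log units; beyond the scatter) on a core different from the one where the exchange was first seen. Both steps run in the same direction, and their sizes cannot be told apart: the same change on two cores in this assay, a 3.6-fold lower number (0.55 log units; beyond the scatter) from compound 1 to compound 2 and an 8.8-fold lower number (0.95 log units; beyond the scatter) from compound 3 to compound 4, 2.5-fold (0.40 log units) apart, within the scatter of two such steps. So, for these two cores, the exchange carried over in direction and in roughly its size, but two pairs cannot show that it would hold on any other core, and they cannot explain why chloro gives the lower number; nor can they separate the effect of the core from that of the exchange's place, which for this pair is ortho to a large group.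

The compounds shown leave open whether the trend from fluoro to chloro would continue with bromo or iodo, or whether a quite different group at the same place, such as methyl, methoxy or nitrile, would give a similar number. They also leave open how an amine or a carboxylic acid at that place would fare on either core.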